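This account rests on a few compounds, and the source may have more. Where it says the series, first, only, none or still open, it means among the compounds named here.

Working notes on the series. For the measured compounds named here, the three compounds measured so far share one core and differ only in the substitution of the phenyl ring attached to it. In an assay on RBL-1 cells for inhibition of Polyunsaturated fatty acid 5-lipoxygenase (Rattus norvegicus) (on this read-out lower numbers stand for stronger inhibition and higher numbers for weaker inhibition), compound 1 `Cc1ccccc1N1CCNC(=O)N1` gives 386000 nM, compound 2 `Cc1cc(C)cc(N2CCNC(=O)N2)c1` gives 12000 nM, and compound 3 `O=C1NCCN(c2cccc(F)c2)N1` gives 19000 nM. On the numbers shown, compound 3 sits second highest of the three; its nearest neighbour is compound 2, whose value lies within the usual scatter of it, while compound 1 stands far above both, a gap that lies beyond the scatter.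

The next compound, compound 4 `CSc1cccc(N2CCNC(=O)N2)c1`, follows from compound 3 by a single exchange: methylsulfanyl in place of fluoro on an aromatic carbon. Going by the values given here, no step between two measured compounds matches this exchange, so nothing measured here tells directly how this assay responds to it. Compound 2 shows that a substituted ring in this position can reach the lower part of the range seen so far, whereas compound 1 shows that substitution can also leave activity very weak. A modest step downward is expected from compound 3 to compound 4, of size a 2.4-fold lower number from compound 3 to compound 4 (0.38 log units; beyond the scatter), which may not exceed the scatter. Compound 4 is therefore estimated at 8000 nM, with a range from 2500 nM to 25000 nM in this assay.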

Compound 4, half-maximal inhibitory concentration: 14000 nM
Compound 4: middle estimate off by 1.8-fold (0.24 log units), on the low side; the range from low to high includes it.
By their numbers in this assay, from the lowest: compounds 2, 4 and 3 (each within the scatter of the next); then compound 1.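

For the compounds shown here, what this adds is the first step read directly at this position: in this assay methylsulfanyl in place of fluoro on an aromatic carbon gives a 1.4-fold lower number from compound 3 to compound 4 (0.13 log units; within the scatter) and so the two groups cannot be told apart on this read-out. The position, meta to a group of 7 heavy atoms, thus takes 2 heavy atoms, 1 of them sulfur, and 1 hydrogen-bond acceptor in place of a single fluorine with no shift that exceeds the scatter. No supporting information is available on why this exchange leaves the number within the scatter.

Going by these compounds alone, this single step covers only two small groups at one place on the ring, so it remains open whether an amine, a carboxylic acid or a longer chain such as butylsulfanyl on the same aromatic carbon would move the number beyond the scatter. Within the data shown here, it also remains open whether methylsulfanyl in place of fluoro would behave the same way on another aromatic carbon of this ring, since the series holds no second example of this exchange.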